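This account rests on a few compounds, and the source may have more. Where it says the series, first, only, none or still open, it means among the compounds named here.

In a functional assay on K562 cells (Homo sapiens) for cytotoxicity, read by CCK-8 assay, with a stated time of 72 h (a higher number here means a weaker inhibitor, a lower number a stronger inhibitor), compound 3 `C=CCn1c(=O)/c(=C\c2cc(F)ccc2C)[nH]c(=O)/c1=C\c1ccccc1OC` gives 1800 nM, the lowest of the two numbers in hand. Compound 1 `C=CCn1c(=O)/c(=C\c2cccc(C)c2)[nH]c(=O)/c1=C\c1ccccc1OC` gives 8800 nM, and compound 2 `C=CCn1c(=O)/c(=C\c2ccc(Cl)c(Cl)c2)[nH]c(=O)/c1=C\c1ccccc1` is reported as "not active" (no number reported). Compound 4 `C=CCn1c(=O)/c(=C\c2cccc(Br)c2)[nH]c(=O)/c1=C\c1ccccc1OC` differs from compound 3 by 3-bromophenyl in place of 5-fluoro-2-methylphenyl on a double-bonded chain carbon bound to an aromatic carbon. Among the compounds with values here, the one measured step that bears on this is a 4.9-fold lower number from compound 1 to compound 3 (0.69 log units; beyond the scatter), where 3-methylphenyl was exchanged for 5-fluoro-2-methylphenyl. Since 3-bromophenyl resembles the 3-methylphenyl of compound 1 more than the 5-fluoro-2-methylphenyl of compound 3, the number is expected to move back toward that of compound 1, with a step of about a 3.3-fold higher number from compound 3 to compound 4 (0.52 log units; beyond the scatter) expected. Compound 4 is therefore estimated at 6000 nM, within a range of 2000 nM to 20000 nM.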

Compound 4, half-maximal inhibitory concentration: 2400 nM
The estimate for compound 4 lay 2.5-fold (0.40 log units) above the measured number, within the range that was stated.
By their numbers in this assay, from the lowest: compounds 3 and 4 (each within the scatter of the next); then compound 1.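

In this assay, 3-bromophenyl in place of 5-fluoro-2-methylphenyl on a double-bonded chain carbon bound to an aromatic carbon gives a 1.3-fold higher number from compound 3 to compound 4 (0.12 log units; within the scatter), so these two differently substituted rings cannot be told apart here. Bromo in place of methyl on an aromatic carbon gives a 3.7-fold lower number from compound 1 to compound 4 (0.56 log units; beyond the scatter), so the fluoro and methyl pair of compound 3 is not the only substitution that brings the number below that of compound 1. No supporting data explain either step. As far as these compounds go, it remains open how an amine or a carboxylic acid on this ring would fare, and whether the bromo can be exchanged for a longer chain.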